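Lengthening the sulfur side chain of compound 1

This account rests on a few compounds, and the source may have more. Where it says the series, first, only, none or still open, it means among the compounds named here.

Compound 1, `Cc1ccc(CCSc2nc3c(c(=O)n(C)c(=O)n3C)n2C)cc1`: 72 nM
Compound 2, `Cn1c(=O)c2c(nc([S+]([O-])CCc3ccc(F)cc3)n2C)n(C)c1=O`: 3500 nM

In an assay on microsomes for inhibition of Amine oxidase [flavin-containing] B (Homo sapiens), read by fluorescence and spectrophotometry, with a stated time of 20 min (a higher number here means a weaker inhibitor, a lower number a stronger inhibitor), compound 1 gives 72 nM, the lower of the two numbers shown. Compound 2 gives 3500 nM, a gap that lies beyond the usual scatter. Compound 3, `Cn1c(=O)c2c(nc(SCCCc3cccc(Cl)c3)n2C)n(C)c1=O`, has not yet been measured. It differs from compound 1 by 3-chlorobenzyl in place of 4-methylphenyl on a saturated chain carbon, two bonds along the chain from a sulfur. Within the data shown here, no measured pair shows a step of this kind, so the expectation rests on compound 1 alone. A small step toward a weaker inhibitor, possibly still within the scatter, is expected, a 1.7-fold higher number from compound 1 to compound 3 (0.22 log units; within the scatter). Compound 3 is therefore expected to give 120 nM in this assay, with a likely range from 30 nM to 500 nM.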

Compound 3, half-maximal inhibitory concentration in the Amine oxidase [flavin-containing] B assay: 62 nM
For compound 3 the middle estimate is 1.9-fold (0.29 log units) above the measured one; low and high end bracket the measured number.
By their numbers in the Amine oxidase [flavin-containing] B assay, from the lowest: compounds 3 and 1 (each within the scatter of the next); then compound 2.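

Placing 3-chlorobenzyl where compound 1 has 4-methylphenyl leaves the two compounds level in the Amine oxidase [flavin-containing] B assay, a 1.2-fold lower number from compound 1 to compound 3 (0.06 log units; within the scatter), so this position tolerates a change in the aromatic group, including the addition of chlorine, without a measurable loss of inhibition. The same change does register in a physicochemical assay for lipophilicity, using the shake flask method, measured as octanol-water partition (on this read-out higher numbers stand for higher lipophilicity and lower numbers for lower lipophilicity), where compound 1 gives 3.15 and compound 3 gives 3.76 and lipophilicity rises: the measured partition coefficient of compound 1, 3.15, and of compound 3, 3.76, a number 0.61 log units higher (beyond the scatter)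

The compounds shown cannot separate the effect of the chlorine from that of the longer chain. On these data alone, how an amine or a carboxylic acid at this position would fare also stays open.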